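Trimming a Pentyl Chain and Cell Tolerance

The source may report more compounds than this note shows. Statements on the series, on what has been measured and on what is new or still open speak of the compounds shown alone.

Of the compounds shown here, two sharing one core have been tested in an ADME assay on HEL cells (Homo sapiens) for cytotoxicity, read by cell counting, with a stated time of 3 days; a higher number here means that more compound is tolerated, a lower number that less compound is tolerated. Compound 1 `CCCCCc1ccc(C#Cc2c(-c3ccc(C)cc3)oc3nc(=O)n([C@H]4C[C@H](OC(C)=O)[C@@H](COC(C)=O)O4)cc23)cc1` gives 20000 nM. Compound 2 `CCCCCc1ccc(-c2oc3nc(=O)n([C@H]4C[C@H](OC(C)=O)[C@@H](COC(C)=O)O4)cc3c2C#CCO)cc1` gives 100000 nM, the highest of the two numbers, standing above compound 1 by a margin that is beyond the usual scatter; in plain terms, cells tolerate more of compound 2 than of compound 1.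

Compound 3 `CC(=O)OC[C@H]1O[C@@H](n2cc3c(C#CCO)c(-c4ccc(C)cc4)oc3nc2=O)C[C@@H]1OC(C)=O` is not yet measured. It differs from compound 2 in one place: hydrogen in place of butyl on a saturated chain carbon bound to an aromatic carbon. The chain on the aromatic ring is shortened from pentyl to methyl, and nothing else changes.

Within the data shown here, no measured pair shows this exact change, so the direction of the step rests on the structures alone. Compound 2 is already the most tolerated compound among the numbers known, and a smaller molecule is not expected to be tolerated less. The step in this assay is expected to be small, no change at the digits printed from compound 2 to compound 3 (within the scatter), or none beyond the scatter. For compound 3 the estimated minimum cytotoxic concentration is 100000 nM, with a range from 50000 nM to 200000 nM.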

Compound 3, minimum cytotoxic concentration: > 100000 nM
Compound 3: no number, only a limit; the forecaster's own chance of this, stated with the estimate: 50%; the middle value sits exactly at the limit.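

In this assay, compound 3 gives > 100000 nM, which is a limit of the assay and not a number. As far as these compounds go, on the saturated chain carbon bound to an aromatic carbon, hydrogen in place of butyl gives a number no lower from compound 2 to compound 3 (the limit leaves the size open), so shortening pentyl to methyl costs no tolerance here, and the tolerance of compound 2 does not depend on the longer chain; any gain from the change stays unknown because the reading stops at the end of the assay's range: the limit of > 100000 nM in this assay, at which 1 of the 3 values shown sits. On a triple-bonded carbon, hydroxymethyl in place of 4-pentylphenyl gives an at least 5.0-fold higher number from compound 1 to compound 3 (0.69 log units; beyond the scatter), which places a readable difference in tolerance on the group at this second position, at least for this pair with methyl on the aromatic ring.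

Whether a longer chain such as octyl, or an amine at the end of the chain, would keep this tolerance remains open, since the compounds shown carry only pentyl and methyl there. From the compounds shown here alone, it is equally open how a carboxylic acid in place of hydroxymethyl on the triple-bonded carbon would behave in cells.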